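From difluoromethyl to trifluoromethyl on a shared core

The source may report more compounds than this note shows. Statements on the series, on what has been measured and on what is new or still open speak of the compounds shown alone.

In an ADME assay on the whole organism (Macaca fascicularis) for metabolic stability, with a stated time of 72 h, at a dose of 1 mg/kg by the oral route (a lower number here means that the compound disappears faster, a higher number that the compound lasts longer), compound 1 `Cc1ncncc1-c1nc2cc(F)c(F)cc2n1C1CC1` gives 4.2 h, while compound 2 `Fc1cc2nc(-c3cncnc3C(F)F)n(C3CC3)c2cc1F` gives 15.3 h. Going by the values given here, compound 2 therefore holds the highest of the two numbers so far, and the gap between them lies beyond the scatter.

Compound 3 `Fc1cc2nc(-c3cncnc3C(F)(F)F)n(C3CC3)c2cc1F` has not yet been measured. It differs from compound 2 by fluoro in place of hydrogen on a saturated chain carbon bound to an aromatic carbon and two fluorine atoms, which turns difluoromethyl into trifluoromethyl.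

Among the compounds with values here, only one measured step bears on this change. Difluoromethyl in place of methyl on an aromatic carbon gave a 3.6-fold higher number from compound 1 to compound 2 (0.56 log units; beyond the scatter), a modest step. A single step does not establish a trend, and the data do not show whether it continues with a further fluoro. Resting on that one step, a smaller move in the same direction is expected in this assay, and the expected step is a 1.4-fold higher number from compound 2 to compound 3 (0.14 log units; within the scatter), which may not clear the scatter. For compound 3 the estimate is 21 h, with a range of 10 h to 42 h.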

Compound 3, half-life: 30 h
Compound 3: the middle estimate sits 1.4-fold (0.15 log units) below what was measured; low and high end bracket the measured number.
By their numbers in this assay, from the lowest: compound 1; then compounds 2 and 3 (each within the scatter of the next).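

Going by these compounds alone, at this position the gain in this assay does not depend on a further fluoro being added to difluoromethyl: the change gives a 2.0-fold higher number from compound 2 to compound 3 (0.29 log units; within the scatter), so compounds 2 and 3 cannot be told apart here, and the single earlier step gains no firm continuation. Measured against the methyl of compound 1, however, trifluoromethyl gives a 7.1-fold higher number from compound 1 to compound 3 (0.85 log units; beyond the scatter), so both fluorinated groups now stand clear of methyl, difluoromethyl through a 3.6-fold higher number from compound 1 to compound 2 (0.56 log units; beyond the scatter) and trifluoromethyl through the step just given, and that separation rests on two compounds rather than one. No measurement is available that would explain these numbers or tie them to any property of the groups.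

The compounds shown carry only methyl, difluoromethyl and trifluoromethyl at this place, so they leave open how a group of another kind, such as a nitrile, a methoxy group or a longer chain like ethyl, would behave on the shared core in this assay. They also leave open whether the separation from methyl would hold on a different core.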